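Swapping the aryl group on sulfur: compound 3

The compounds below may be only part of what the source reports. "The series", "measured", "known", "first", "only" and "open" are said of these compounds alone.

Of the compounds shown here, two have been read so far in a functional assay on HCT-116 cells (Homo sapiens) for inhibition, read by CCK-8 assay, with a stated time of 72 h, tested at 8 uM; a higher number here means more inhibition of growth at the concentration tested, a lower number less inhibition of growth. Compound 1 `Nc1ccccc1NC(=O)/C=C/c1ccc(CSc2cccc(F)c2)cc1` gives 3.22% and compound 2 `CCc1ccc(SCc2ccc(/C=C/C(=O)Nc3ccccc3N)cc2)cc1` gives 2.68%. These two values lie within the scatter of each other, and both show little inhibition of growth.

The next structure, compound 3 `Nc1ccccc1NC(=O)/C=C/c1ccc(CSc2cccc3ccccc23)cc1`, keeps the core of compound 2 and changes one group: naphthalen-1-yl in place of 4-ethylphenyl on a sulfur. In words, naphthalen-1-yl stands in place of 4-ethylphenyl on a sulfur.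

Within the data shown here, one measured step bears on this change, at the same place: a number 0.5 percentage points lower from compound 1 to compound 2 (within the scatter). That step stayed within the scatter. Among the measured compounds shown here, it is a single step, however, and no measured compound carries naphthalen-1-yl, so the evidence for a second six-membered aromatic ring at this place is thin.

From the compounds shown here alone, no step beyond the scatter is expected in this assay, and the direction stays open. The expected move is a number 1.3 percentage points higher from compound 2 to compound 3 (within the scatter), which is an estimate and not a measurement. For compound 3 the estimated value is 4%, with an expected range from -3% to 14%.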

Compound 3, percent growth inhibition at one concentration: 35.2%
Beside the measured number, compound 3's estimate is 31.2 percentage points below it; measured number outside the range, above it.
By their numbers in this assay, from the lowest: compounds 2 and 1 (each within the scatter of the next); then compound 3.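

In this assay, the aryl group on a sulfur proves able to change the read-out: the change to naphthalen-1-yl from 4-ethylphenyl gives a number 32.5 percentage points higher from compound 2 to compound 3 (beyond the scatter), and the change to naphthalen-1-yl from 3-fluorophenyl gives a number 32 percentage points higher from compound 1 to compound 3 (beyond the scatter). Compound 1 and compound 2, each with one six-membered aromatic ring of carbon only at this place, stay within the scatter of each other, so that pair gave no sign that this place could respond; the large steps appear only with 2 six-membered aromatic rings of carbon only. Nothing at hand accounts for the size of these steps.

Among these compounds, with compound 3 as the only example of naphthalen-1-yl, the data do not separate the second aromatic ring from the larger count of heavy atoms, or show whether the steps depend on how that ring system is attached to the sulfur. A longer chain or an amine on the sulfur in place of the aryl group would test whether an aromatic ring is required at this place at all.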